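Chloro on the 2-fluorophenyl group of compound 2

A few compounds are considered here, and "the series" means these few. Any claim that something is new, unique, unknown or untested is made for them only; others in the source may bear on it.

Of the compounds shown here, two on the shared core have been read so far in a functional assay on U-87MG ATCC cells for inhibition, with U-87 MG (Homo sapiens) as the target, read by MTT assay, with a stated time of 72 h (a lower number here means a stronger inhibitor, a higher number a weaker inhibitor), so far. Compound 1 `Oc1c(C(Nc2ccccn2)c2ccccc2F)ccc2cccnc12` reports only a limit, > 10000 nM, and not a number. For the measured compounds named here, compound 2 `Cc1ccnc(NC(c2ccccc2F)c2ccc3cccnc3c2O)c1` gives 13100 nM, the only true number, so it cannot yet be ranked against a measured neighbour. Going by the values given here, the one measured step, a step that the limit leaves unreadable from compound 1 to compound 2, is methyl in place of hydrogen and carries no size forward; the evidence on it is the limit of > 10000 nM in this assay, at which 1 of the 2 values shown sits.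

Compound 3 `Cc1ccnc(NC(c2ccc3cccnc3c2O)c2c(F)cccc2Cl)c1` turns 2-fluorophenyl into 2-chloro-6-fluorophenyl, with chloro in place of hydrogen on an aromatic carbon, ortho to a large group and meta to the fluoro group: chloro in place of hydrogen on an aromatic carbon. Among the compounds with values here, no measured step involves a chloro group, so the size of this change has no direct precedent. With compound 2 at 13100 nM as the sole anchor, no step beyond the scatter is expected in this assay, in either direction. The expected step is a 1.3-fold lower number from compound 2 to compound 3 (0.12 log units; within the scatter), with wide uncertainty. Compound 3 is estimated at 10000 nM, with an expected range from 3500 nM to 25000 nM.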

Compound 3, half-maximal inhibitory concentration: 20600 nM
Compound 3: the middle estimate sits 2.1-fold (0.31 log units) below what was measured; low and high end bracket the measured number.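

In this assay, chloro in place of hydrogen on an aromatic carbon, ortho to a large group and meta to a fluoro group, gives a 1.6-fold higher number from compound 2 to compound 3 (0.20 log units; within the scatter). For the compounds shown here, this is the only step with a readable size, and it does not separate the 2-chloro-6-fluorophenyl group of compound 3 from the 2-fluorophenyl group of compound 2; the step from compound 1 to compound 2 cannot be read. So this position accepts a chloro group without a change that can be told from assay scatter, though the series offers little room for finer reading, with one of its values still a limit and not a number: the limit of > 10000 nM in this assay, at which 1 of the 3 values shown sits.

Still open, going by these compounds, is whether a methoxy group, an amine or a carboxylic acid on the same aromatic carbon would move the number beyond the scatter in either direction. Also open, on these data alone, is whether the chloro step would read the same on the core of compound 1, without the methyl group that compound 2 and compound 3 share.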